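This account rests on a few compounds, and the source may have more. Where it says the series, first, only, none or still open, it means among the compounds named here.

Compound 1 `CCN(CC)CCNC(=O)c1ccc(C(CC)(CC)c2ccc(OCS(=O)(=O)c3ccccc3)c(C)c2)n1CC` stands lowest of the two numbers measured here: in a functional assay on MCF7 cells (Homo sapiens) for antiproliferative activity, read by MTT assay, with a stated time of 24 h (a higher number here means a weaker inhibitor, a lower number a stronger inhibitor), compound 1 gives 4680 nM. Its neighbour compound 2 `CCn1c(C(=O)N[C@H](C)CO)ccc1C(CC)(CC)c1ccc(OCS(=O)(=O)c2ccccc2)c(C)c1` gives 10600 nM in this assay, and the step between them, a 2.3-fold higher number from compound 1 to compound 2 (0.36 log units; beyond the scatter), follows the exchange of 2-(diethylamino)ethyl for 1-(hydroxymethyl)ethyl on the amide-type nitrogen. Compound 3 `CCn1c(C(=O)N[C@H](CO)CCO)ccc1C(CC)(CC)c1ccc(OCS(=O)(=O)c2ccccc2)c(C)c1` is the unmeasured member and differs from compound 1 in one place: 3-hydroxy-1-(hydroxymethyl)propyl in place of 2-(diethylamino)ethyl on an amide-type nitrogen. Among the compounds with values here, the only measured step that bears on this change is the one from compound 1 to compound 2, since both changes remove the 2-(diethylamino)ethyl group from the same nitrogen and bring in a hydroxyl-bearing chain. A step of about that size, toward a higher number, is therefore expected for a 2.4-fold higher number from compound 1 to compound 3 (0.37 log units; beyond the scatter). In this assay compound 3 is estimated at 11000 nM, with a likely range from 4500 nM to 27000 nM.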

Compound 3, half-maximal inhibitory concentration: 28500 nM
For compound 3 the middle estimate is 2.6-fold (0.41 log units) below the measured one; the measured number lies above the stated range.
By their numbers in this assay, from the lowest: compound 1; then compound 2; then compound 3.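

In this assay, replacing 2-(diethylamino)ethyl on the amide-type nitrogen with 3-hydroxy-1-(hydroxymethyl)propyl gives a 6.1-fold higher number from compound 1 to compound 3 (0.78 log units; beyond the scatter), a larger step than the earlier pair showed. The two incoming chains also differ from each other, with a 2.7-fold higher number from compound 2 to compound 3 (0.43 log units; beyond the scatter), so the result at this position depends on which chain enters and not only on 2-(diethylamino)ethyl leaving. Nothing at hand explains these differences.

The three compounds leave open whether another amine on this nitrogen, such as a 2-(dimethylamino)ethyl or a piperidine-bearing chain, would stay close to compound 1. They also leave open how a carboxylic acid, a longer chain carrying a single hydroxyl, or the mirror-image form of either hydroxyl-bearing chain would compare.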